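Sulfonyl aryl exchange on a methoxy-bearing core

The source may report more compounds than this note shows. Statements on the series, on what has been measured and on what is new or still open speak of the compounds shown alone.

Three quinoline sulfones have been measured in an assay on isolated protein for displacement of a labelled ligand from metabotropic glutamate receptor 5 (Homo sapiens), with a stated time of 60 min, tested at 1 uM; a lower number here means less inhibition, a higher number more inhibition at the concentration tested (going by the name of the read-out). Compound 2 `COc1cccc(S(=O)(=O)c2cnc3ccc(Cl)cc3c2N2CCC(C)CC2)c1` gives 87%. Compound 1 `Cc1ccc(S(=O)(=O)c2cnc3ccc(Cl)cc3c2N2CCC(C)CC2)cc1F` gives 68%. Compound 3 `COc1cccc(S(=O)(=O)c2cnc3ccc(OC)cc3c2N2CCC(C)CC2)c1` gives 0%, the lowest of the three numbers.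

Compound 1 differs from compound 2 by one change, (3-fluoro-4-methylphenyl in place of 3-methoxyphenyl on a sulfonyl sulfur), and that change made a step of a number 19 percentage points lower from compound 2 to compound 1 (beyond the scatter). Compound 3 differs from compound 2 in the core, (methoxy in place of chloro on an aromatic carbon), and that change made a step of a number 87 percentage points lower from compound 2 to compound 3 (beyond the scatter).

Compound 4 `COc1ccc2ncc(S(=O)(=O)c3ccc(C)c(F)c3)c(N3CCC(C)CC3)c2c1` has not been measured. Going by the values given here, it differs from compound 3 by 3-fluoro-4-methylphenyl in place of 3-methoxyphenyl on a sulfonyl sulfur, which is the same change as the one from compound 2 to compound 1, made on the same place. That change occurs twice among the compounds shown. On the core of compound 2 it lowered the number by a modest amount; compound 3, which shares its core with compound 4, already stands at the floor of the read-out.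

Compound 4 is therefore expected to show a step of a number 3 percentage points higher from compound 3 to compound 4 (within the scatter), an estimate that rests on compound 3 standing at 0% and on the earlier step of a number 19 percentage points lower from compound 2 to compound 1 (beyond the scatter) pointing downward rather than upward. In this assay compound 4 is estimated at 3%, with a range from -8% to 18%.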

Compound 4, a percentage reported as inhibition, at one concentration (the size of the read-out at that concentration, not a potency): 73%
The estimate for compound 4 lay 70 percentage points below the measured number; measured number outside the range, above it.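

On the methoxy-bearing core, 3-fluoro-4-methylphenyl in place of 3-methoxyphenyl on a sulfonyl sulfur gave a number 73 percentage points higher from compound 3 to compound 4 (beyond the scatter) in this assay, so the change did not carry over from the chloro-bearing core in either direction or size: the same change on two cores in this assay, a number 19 percentage points lower (beyond the scatter) from compound 2 to compound 1 and a number 73 percentage points higher (beyond the scatter) from compound 3 to compound 4, 92 percentage points apart, beyond the scatter of two such steps

Seen from the other side of the same four compounds, methoxy in place of chloro on an aromatic carbon gave a number 5 percentage points higher from compound 1 to compound 4 (within the scatter) when the sulfonyl group was 3-fluoro-4-methylphenyl, which does not match what the same change did with 3-methoxyphenyl: the same change on two cores in this assay, a number 87 percentage points lower (beyond the scatter) from compound 2 to compound 3 and a number 5 percentage points higher (within the scatter) from compound 1 to compound 4, 92 percentage points apart, beyond the scatter of two such steps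

Within these four compounds, then, the outcome of each change depends on the group present at the other place, so a step read on one core cannot be transferred to the other; this does not show why the two places are coupled, or whether the coupling extends to any other group, and each number is a single read-out at one concentration, not a potency.

The compounds shown leave open whether the loss seen in compound 3 is particular to the pairing of its two methoxy-bearing groups. They also leave open what a nitrile or an amine would do on the aromatic carbon that carries chloro or methoxy, or an unsubstituted phenyl on the sulfonyl sulfur.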